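This account rests on a few compounds, and the source may have more. Where it says the series, first, only, none or still open, it means among the compounds named here.

In an ADME assay on BHK-21 cells (Mesocricetus auratus) for cytotoxicity, read by MTT assay, with a stated time of 72 h (on this read-out higher numbers stand for lower toxicity in this test and lower numbers for higher toxicity in this test), compound 2 (`NS(=O)(=O)c1ccc(N2N=C(c3ccc(OCc4ccccc4)cc3)CC2c2ccc(F)cc2)cc1`) gives 60000 nM, the highest of three numbers, with compound 1 (`NS(=O)(=O)c1ccc(N2N=C(c3ccccc3)CC2c2ccccc2F)cc1`) at 21000 nM and compound 3 (`NS(=O)(=O)c1ccc(N2N=C(c3ccc(Oc4ccccc4)cc3)CC2c2ccc(F)cc2)cc1`) at 8000 nM. Compound 4 (`NS(=O)(=O)c1ccc(N2N=C(c3ccc(OCc4ccccc4)cc3)CC2c2cccc(Cl)c2)cc1`), not yet measured, carries 3-chlorophenyl in place of 4-fluorophenyl on a saturated ring carbon. Within the data shown here, the only measured step, a 7.5-fold lower number from compound 2 to compound 3 (0.88 log units; beyond the scatter), replaces benzyl with phenyl on an oxygen on an aromatic ring, so it bears only indirectly on this change. Among the measured compounds shown here, no measured step alters the group on the saturated ring carbon alone. No shift beyond the scatter is therefore expected, and the estimated step is a 1.3-fold lower number from compound 2 to compound 4 (0.12 log units; within the scatter). Compound 4 is expected at 45000 nM, within an estimated range of 18000 nM to 100000 nM.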

Compound 4, half-maximal cytotoxic concentration: 45000 nM
Estimate against measurement, compound 4: no gap at the digits printed; the range from low to high includes it.
By their numbers in this assay, from the lowest: compound 3; then compound 1; then compounds 4 and 2 (each within the scatter of the next).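

In this assay, among these compounds, the first step at the saturated ring carbon, 3-chlorophenyl in place of 4-fluorophenyl, is a 1.3-fold lower number from compound 2 to compound 4 (0.12 log units; within the scatter), so the two compounds cannot be told apart at this position. The step on the oxygen, a 7.5-fold lower number from compound 2 to compound 3 (0.88 log units; beyond the scatter), by contrast lies beyond the scatter. Nothing measured on these compounds bears on this result.

On these data alone, whether an amine or a carboxylic acid on the saturated ring carbon would also stay within the scatter remains open. So does whether the same exchange would read alike with phenyl on the oxygen, as in compound 3.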